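A few compounds are considered here, and "the series" means these few. Any claim that something is new, unique, unknown or untested is made for them only; others in the source may bear on it.

In a functional assay on DU-145 cells (Homo sapiens) for antiproliferative activity, read by MTT assay, with a stated time of 72 h; on this read-out higher numbers stand for weaker inhibition and lower numbers for stronger inhibition:
- compound 1 `CCN(c1ccc(C)cc1)S(=O)(=O)C1CC2OC1C(c1ccc(NC(=O)CCCCCCC(=O)O)cc1)=C2c1ccc(O)cc1`: 53500 nM
- compound 2 `CCN(c1ccccc1Cl)S(=O)(=O)C1CC2OC1C(c1ccc(NC(=O)CCCCCCC(=O)O)cc1)=C2c1ccc(O)cc1`: > 100000 nM, a limit

Compound 2 stands at the limit of > 100000 nM in this assay, at which 1 of the 2 values shown sits. Compound 3 `CCN(c1ccc(Cl)cc1)S(=O)(=O)C1CC2OC1C(c1ccc(NC(=O)CCCCCCC(=O)O)cc1)=C2c1ccc(O)cc1` is not yet measured. It differs from compound 2 by 4-chlorophenyl in place of 2-chlorophenyl on a sulfonamide nitrogen. Within the data shown here, the one measured step that bears on this is an at least 1.8-fold higher number from compound 1 to compound 2 (0.27 log units; that floor lies within the scatter), which replaced 4-methylphenyl with 2-chlorophenyl. Undoing that change in part suggests a modest move towards a lower number in this assay, so compound 3 should land near compound 1. The expected change is an at least 1.8-fold lower number from compound 2 to compound 3 (0.25 log units; that floor lies within the scatter). For compound 3 the estimated value is 55000 nM, with an expected range of 25000 nM to 100000 nM.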

Compound 3, half-maximal inhibitory concentration: 42100 nM
Compound 3: the middle estimate sits 1.3-fold (0.12 log units) above what was measured; low and high end bracket the measured number.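

In this assay, the site of the chlorine on the phenyl group matters: 4-chlorophenyl in place of 2-chlorophenyl on a sulfonamide nitrogen gives an at least 2.3-fold lower number from compound 2 to compound 3 (0.37 log units; beyond the scatter). Compound 2 has only a limit, so this step has a floor and no exact size: the limit of > 100000 nM in this assay, at which 1 of the 3 values shown sits. Chloro in place of methyl on an aromatic carbon gives a 1.3-fold lower number from compound 1 to compound 3 (0.10 log units; within the scatter), so this read-out does not separate 4-chlorophenyl from 4-methylphenyl.

The compounds shown leave open whether fluoro or an amine in place of that chloro would shift the number. They also leave open whether any group on this phenyl ring could give a number far lower than those of compound 1 and compound 3.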